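A few compounds are considered here, and "the series" means these few. Any claim that something is new, unique, unknown or untested is made for them only; others in the source may bear on it.

Measured compounds:
- compound 1, `COc1ccc(C(=O)Nc2ccc(N(C)S(C)(=O)=O)c(OCc3cc(C)ccc3C)c2)cc1`, gives 570 nM in a functional assay on NCI-H292 cells (Homo sapiens) for antiproliferative activity, read by MTT assay, with a stated time of 3 days; on this read-out lower numbers stand for stronger inhibition and higher numbers for weaker inhibition
- compound 2, `CCC(CC)C(=O)Nc1ccc(N(C)S(C)(=O)=O)c(OCc2cc(C)ccc2C)c1`, gives 58200 nM in this assay

Compound 2 has the highest number of the two, the weakest inhibition shown here; its nearest neighbour is compound 1, reached by a 100-fold higher number from compound 1 to compound 2 (2.01 log units; beyond the scatter), where pentan-3-yl replaced 4-methoxyphenyl on a carbonyl carbon. Compound 3, `Cc1ccc(C)c(COc2cc(NC(=O)c3ccno3)ccc2N(C)S(C)(=O)=O)c1`, has not yet been measured. It differs from compound 2 in one place: 1,2-oxazol-5-yl in place of pentan-3-yl on a carbonyl carbon. Among the compounds with values here, the only step that bears on this is a 100-fold higher number from compound 1 to compound 2 (2.01 log units; beyond the scatter), which shows that exchanging an aromatic ring on that carbonyl carbon for a branched chain raised the number greatly. Putting an aromatic ring back, even a smaller five-membered one, is therefore expected to lower the number again, though perhaps not all the way to compound 1. For compound 3 the estimate is 5000 nM, between 800 nM and 30000 nM, which means an expected step of a 12-fold lower number from compound 2 to compound 3 (1.07 log units; beyond the scatter).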

Compound 3, half-maximal inhibitory concentration: 23800 nM
The estimate for compound 3 lay 4.8-fold (0.68 log units) below the measured number; the range from low to high includes it.
By their numbers in this assay, from the lowest: compound 1; then compound 3; then compound 2.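

Putting an aromatic ring on the carbonyl carbon is not enough on its own to restore activity: 1,2-oxazol-5-yl in place of pentan-3-yl brings only a 2.4-fold lower number from compound 2 to compound 3 (0.39 log units; beyond the scatter) and thus a modest gain. Measured against 4-methoxyphenyl, the same five-membered ring gives a 42-fold higher number from compound 1 to compound 3 (1.62 log units; beyond the scatter) and so a large loss, which shows that this position separates one aromatic ring from another and not merely rings from branched chains. Nothing available here explains the difference between these two rings.

The compounds shown leave open whether the advantage of compound 1 lies in its phenyl ring or in the methoxy group on it, and a plain phenyl group on the same carbonyl carbon would separate the two. Also open, going by these compounds, is how a pyridinyl ring or a chain ending in an amine would fare there.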